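A New Group on the Amine Nitrogen of Compound 2

The source may report more compounds than this note shows. Statements on the series, on what has been measured and on what is new or still open speak of the compounds shown alone.

Compound 1 `CCOC(=O)C1=C(NN=C(C(C)=O)C(C)=O)Nc2[nH]nc(C)c2C1c1ccc(N(C)C)cc1`: 8480 nM
Compound 2 `CCOC(=O)C1=C(N)Nc2[nH]nc(C)c2C1c1ccc(N(C)C)cc1`: 4240 nM

For the measured compounds named here, in a functional assay on HepG2 cells (Homo sapiens) for inhibition, read by MTT assay, with a stated time of 48 h (a lower number here means a stronger inhibitor, a higher number a weaker inhibitor), compound 2 stands within the scatter of compound 1, the only other compound measured. Compound 3 `CCOC(=O)C1=C(N/N=C(/Cl)C#N)Nc2[nH]nc(C)c2C1c1ccc(N(C)C)cc1` differs from compound 2 by a group of 5 heavy atoms (2 carbon, 2 nitrogen, 1 chlorine; no ring) in place of a hydrogen atom, on an amine nitrogen and carries no other change. Going by the values given here, one measured step bears on this, a 2.0-fold lower number from compound 1 to compound 2 (0.30 log units; within the scatter) and it also concerns a group on an amine nitrogen. Read in reverse, it points to a slightly higher number at most, with no shift beyond the scatter expected in this assay here. The expected step is a 1.4-fold higher number from compound 2 to compound 3 (0.15 log units; within the scatter) and no more than that is estimated. For compound 3 the estimate is 6000 nM with 2000 nM and 18000 nM as its expected bounds.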

Compound 3, half-maximal inhibitory concentration: 23600 nM
For compound 3 the middle estimate is 3.9-fold (0.59 log units) below the measured one, and the stated range ends below it.
By their numbers in this assay, from the lowest: compounds 2 and 1 (each within the scatter of the next); then compound 3.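

In this assay, the amine nitrogen proves sensitive to what it carries: the group of 5 heavy atoms gives a 5.6-fold higher number from compound 2 to compound 3 (0.75 log units; beyond the scatter), whereas the earlier change stayed within the scatter. The larger group of 8 heavy atoms does not produce the same result, and exchanging it for the smaller group gives a 2.8-fold higher number from compound 1 to compound 3 (0.44 log units; beyond the scatter), so the heavy-atom count alone does not order these three compounds. No evidence is available to explain these shifts. The compounds shown leave open whether the chlorine itself matters, as a bromine or a methyl group in its place would show.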